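Aryl variation on the shared aminothiophene-free core: compound 4

A few compounds are considered here, and "the series" means these few. Any claim that something is new, unique, unknown or untested is made for them only; others in the source may bear on it.

Measured so far:
compound 1 `COc1cc(C(=O)c2sc(-c3ccc(C(F)(F)F)cc3)cc2N)cc(OC)c1OC`: 540 nM
compound 2 `COc1cc(C(=O)c2sc(-c3ccsc3)cc2N)cc(OC)c1OC`: 3.7 nM
compound 3 `COc1cc(C(=O)c2sc(-c3ccc([N+](=O)[O-])cc3)cc2N)cc(OC)c1OC`: 64 nM

In a functional assay on FM3A cells (Mus musculus) for antiproliferative activity (on this read-out lower numbers stand for stronger inhibition and higher numbers for weaker inhibition), compound 3 stands second highest of the three numbers; compound 1 lies an 8.4-fold lower number from compound 1 to compound 3 (0.93 log units; beyond the scatter) away, compound 2 further, with a 17-fold higher number from compound 2 to compound 3 (1.24 log units; beyond the scatter). Compound 4 `COc1cc(C(=O)c2sc(-c3ccccc3Cl)cc2N)cc(OC)c1OC` differs from compound 3 by 2-chlorophenyl in place of 4-nitrophenyl on an aromatic carbon. Among the compounds with values here, two measured steps touch the same position: an 8.4-fold lower number from compound 1 to compound 3 (0.93 log units; beyond the scatter) changes only the group on the phenyl, while a 17-fold higher number from compound 2 to compound 3 (1.24 log units; beyond the scatter) exchanges the whole aryl, and a 150-fold lower number from compound 1 to compound 2 (2.16 log units; beyond the scatter) links the remaining pair. Within the data shown here, no step tests a 2-chlorophenyl, so the direction is open; a modest step in this assay, not clearly beyond the scatter, is expected. For compound 4 the estimate is 100 nM, range 20 nM to 600 nM, corresponding to an expected 1.6-fold higher number from compound 3 to compound 4 (0.19 log units; within the scatter).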

Compound 4, half-maximal inhibitory concentration: 34 nM
Compound 4: middle estimate off by 2.9-fold (0.47 log units), on the high side; the range from low to high includes it.
By their numbers in this assay, from the lowest: compound 2; then compounds 4 and 3 (each within the scatter of the next); then compound 1.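

In this assay the aryl on the carbon next to the ring sulfur tolerates 2-chlorophenyl as well as 4-nitrophenyl (a 1.9-fold lower number from compound 3 to compound 4 (0.27 log units; within the scatter)), so these two substituted phenyls cannot be told apart. Substituted phenyls are not all equal, though: 2-chlorophenyl clearly outperforms 4-(trifluoromethyl)phenyl (a 16-fold lower number from compound 1 to compound 4 (1.20 log units; beyond the scatter)), yet still falls short of thiophen-3-yl (a 9.2-fold higher number from compound 2 to compound 4 (0.96 log units; beyond the scatter)). Nothing available explains these differences. Still open, from the compounds shown here alone, is whether 4-chlorophenyl reads like 2-chlorophenyl. Also open, going by these compounds, is how unsubstituted phenyl, or a phenyl carrying an amine or a carboxylic acid, compares.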